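Cytotoxicity Outlook for a Nitrophenyl Amide Analogue

This account rests on a few compounds, and the source may have more. Where it says the series, first, only, none or still open, it means among the compounds named here.

Going by the values given here, compound 2 `CC(=O)Oc1ccc(/C=C/S(=O)(=O)CCc2ccc(NC(=O)C3CCCCC3)cc2)cc1OC(C)=O` stands at one end of the two numbers measured so far in an ADME assay on TZM cells (Homo sapiens) for cytotoxicity, read by CCK-8 assay, with a stated time of 2 days (a higher number here means that more compound is tolerated, a lower number that less compound is tolerated), where compound 2 gives 169000 nM; its only neighbour is compound 1 `CC(=O)Oc1ccc(/C=C/S(=O)(=O)CCc2ccc(NC(=O)c3cc(F)cc(F)c3)cc2)cc1OC(C)=O`, which in this assay gives 225000 nM, a gap within the scatter. Among the compounds with values here, the single measured step, a 1.3-fold lower number from compound 1 to compound 2 (0.12 log units; within the scatter), is the only precedent for changing the group on the carbonyl carbon. Compound 3 `CC(=O)Oc1ccc(/C=C/S(=O)(=O)CCc2ccc(NC(=O)c3ccc([N+](=O)[O-])cc3)cc2)cc1OC(C)=O` differs from compound 2 by 4-nitrophenyl in place of cyclohexyl on a carbonyl carbon. This reverses the kind of change seen in the measured step, returning an aromatic ring to the carbonyl carbon, here the 4-nitrophenyl. Because a 1.3-fold lower number from compound 1 to compound 2 (0.12 log units; within the scatter) lay within the scatter, no move beyond the scatter is expected, and the estimated step is a 1.2-fold higher number from compound 2 to compound 3 (0.07 log units; within the scatter). Compound 3 is therefore expected to give about 200000 nM in this assay, within a range from 100000 nM to 400000 nM.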

Compound 3, half-maximal cytotoxic concentration: 160000 nM
The estimate for compound 3 lay 1.3-fold (0.10 log units) above the measured number; measured number inside the range.
By their numbers in this assay, from the lowest: compounds 3, 2 and 1 (each within the scatter of the next).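

In this assay the change from cyclohexyl to 4-nitrophenyl on the carbonyl carbon gives a 1.1-fold lower number from compound 2 to compound 3 (0.02 log units; within the scatter) and the change from 3,5-difluorophenyl to 4-nitrophenyl gives a 1.4-fold lower number from compound 1 to compound 3 (0.15 log units; within the scatter) at the same place. A second aromatic ring at this position, this one carrying nitrogen and oxygen atoms and hydrogen-bond acceptors that cyclohexyl does not have, thus leaves the number within the scatter of both neighbours, so that all three groups now read alike in this assay. No accompanying measurement bears on this result.

All three groups seen here are uncharged six-membered rings. The compounds shown leave open whether an amine, a carboxylic acid or a longer chain on this carbonyl carbon would move the number beyond the scatter.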